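This account rests on a few compounds, and the source may have more. Where it says the series, first, only, none or still open, it means among the compounds named here.

Three compounds have been measured in a functional assay on MDA-MB-231 cells (Homo sapiens) for cytotoxicity, read by MTT assay, with a stated time of 72 h; on this read-out higher numbers stand for weaker inhibition and lower numbers for stronger inhibition:

Compound 1, `FC(F)(F)c1ccc(CSc2nc(Nc3ccccc3C(F)(F)F)c3ccccc3n2)cc1`: > 50000 nM, a limit of the assay rather than a number.
Compound 2, `FC(F)(F)c1ccc(CSc2nc(Nc3cccc(C(F)(F)F)c3)c3ccccc3n2)cc1`: 11100 nM.
Compound 3, `FC(F)(F)c1ccc(CSc2nc(Nc3cccc(Cl)c3)c3ccccc3n2)cc1`: 18000 nM.

For the measured compounds named here, compound 3 is one of only two compounds with a number; compound 2 is its nearest neighbour, and the two sit within the scatter of each other: a 1.6-fold higher number from compound 2 to compound 3 (0.21 log units; within the scatter). Compound 1 sits at the limit of > 50000 nM in this assay, at which 1 of the 3 values shown sits.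

Compound 4, `O=[N+]([O-])c1ccc(Nc2nc(SCc3ccc(C(F)(F)F)cc3)nc3ccccc23)cc1`, differs from compound 3 in one place: 4-nitrophenyl in place of 3-chlorophenyl on a nitrogen on an aromatic ring. The measured steps that bear on this all alter the same aryl group on that nitrogen. Two of them are clearly beyond the scatter: an at least 4.5-fold lower number from compound 1 to compound 2 (0.65 log units; beyond the scatter) and an at least 2.7-fold lower number from compound 1 to compound 3 (0.44 log units; beyond the scatter). The third, between the two aryl groups that carry a substituent at the 3-position, was within the scatter. Going by the values given here, no measured step introduces a nitro group or places a substituent at the 4-position, so there is no direct precedent for compound 4. The expected step from compound 3 to compound 4 is therefore small, a 1.2-fold lower number from compound 3 to compound 4 (0.08 log units; within the scatter), in either direction and not beyond the scatter. Compound 4 is estimated at 15000 nM, with a range of 4000 nM to 55000 nM.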

Compound 4, half-maximal inhibitory concentration: 8670 nM
Compound 4: the middle estimate sits 1.7-fold (0.24 log units) above what was measured; low and high end bracket the measured number.
By their numbers in this assay, from the lowest: compounds 4, 2 and 3 (each within the scatter of the next, the first and the last beyond it). At a limit, above all of these: compound 1.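

Compound 4 shows that, in this assay, the aryl group on this nitrogen can give a number and not only a limit with something other than 3-chlorophenyl or 3-(trifluoromethyl)phenyl: 4-nitrophenyl does so too. Replacing 3-chlorophenyl gives a 2.1-fold lower number from compound 3 to compound 4 (0.32 log units; beyond the scatter), a modest gain, while replacing 3-(trifluoromethyl)phenyl gives a 1.3-fold lower number from compound 2 to compound 4 (0.11 log units; within the scatter), so 4-nitrophenyl cannot be told apart from that group here. The largest gap remains the one to 2-(trifluoromethyl)phenyl, an at least 5.7-fold lower number from compound 1 to compound 4 (0.76 log units; beyond the scatter), and this step is only a bound, since compound 1 stands at a limit and not at a number: the limit of > 50000 nM in this assay, at which 1 of the 4 values shown sits.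

Compound 4 changes both the substituent and its place on the phenyl ring relative to compound 3, and the compounds shown do not separate these two changes, which a 4-chlorophenyl group in the same place would begin to do. Also open, going by these compounds, is how this position responds to a 4-aminophenyl or a 4-carboxyphenyl group, and whether any of these steps would hold with a different group on the sulfur.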